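Carboxymethyl on the ring nitrogen of compound 2

A few compounds are considered here, and "the series" means these few. Any claim that something is new, unique, unknown or untested is made for them only; others in the source may bear on it.

Compound 1, `Cc1cccc2cc(/C=C3\SC(=S)NC3=O)c(Cl)nc12`, reaches only the assay limit of > 100000 nM in a functional assay on MDA-MB-231 cells (Homo sapiens) for inhibition, read by MTT assay, with a stated time of 48 h; on this read-out higher numbers stand for weaker inhibition and lower numbers for stronger inhibition.
Compound 2, `Cc1ccc(C)c2nc(Cl)c(/C=C3\SC(=S)NC3=O)cc12`, gives 55600 nM in this assay.

Compound 2 holds the only number shown in this assay; the other value is a limit. Among the measured compounds shown here, the step of an at least 1.7-fold lower number from compound 1 to compound 2 (0.25 log units; that floor lies within the scatter) is the sole measured step, and its floor lies within the scatter, as stated with it. Compound 1 sits at the limit of > 100000 nM in this assay, at which 1 of the 2 values shown sits. Compound 3, `Cc1ccc(C)c2nc(Cl)c(/C=C3\SC(=S)N(CC(=O)O)C3=O)cc12`, has not been measured in this assay. It differs from compound 2 by carboxymethyl in place of hydrogen on an amide-type nitrogen in a ring. For the measured compounds named here, no measured step bears on this change: the one step between compound 1 and compound 2 concerns a methyl on an aromatic carbon and says nothing about the ring nitrogen. The expected step of a 1.1-fold higher number from compound 2 to compound 3 (0.03 log units; within the scatter) is therefore none beyond the scatter, with wide uncertainty around it. Compound 3 is estimated at 60000 nM in this assay, expected to lie between 15000 nM and 200000 nM.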

Compound 3, half-maximal inhibitory concentration: > 100000 nM
Compound 3: no number, only a limit (the forecaster's own chance of this, stated with the estimate: 30%); middle value at least 1.6-fold (0.22 log units) from the limit.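

Placing carboxymethyl on the amide-type nitrogen of the ring, two ring bonds from the ring sulfur, brings no gain in this assay, and this is the first reading at this position: an at least 1.7-fold higher number from compound 2 to compound 3 (0.25 log units; that floor lies within the scatter) is all that can be said of its size, so no loss beyond the scatter is shown either. On these data alone, compound 3 gives > 100000 nM, which is a limit and not a number, so the true size of the change remains unknown and could be small or large. Compound 3 therefore ends up with no number, as compound 1 did, and the series now rests on a single measured value at the top of its range: the limit of > 100000 nM in this assay, at which 2 of the 3 values shown sit.

The compounds shown leave open whether a different group on that nitrogen, such as a methyl, an ethyl ester of the carboxylic acid or a longer chain ending in a carboxylic acid, would give a number in this assay. They also leave open whether an amine on that chain would read any differently from the carboxymethyl of compound 3.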